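From Methoxy to Acetamido: Expected Tolerance of Compound 4

The source may hold more compounds than are shown below. What is called first, only, known or untested is meant among the compounds shown, and "the series" means these compounds.

Compound 1 `Oc1ccc(-c2nc3cc(C(F)(F)F)ccc3[nH]2)cc1` — in an ADME assay on Vero cells (Chlorocebus sabaeus) for cytotoxicity (a higher number here means that more compound is tolerated, a lower number that less compound is tolerated), compound 1 gives > 100000 nM, a limit of the assay rather than a number.
Compound 2 `COc1ccc(-c2nc3cc(C(F)(F)F)ccc3[nH]2)c(OC)c1` — in this assay compound 2 gives > 100000 nM, again a limit.
Compound 3 `COc1ccc(-c2nc3cc(C(F)(F)F)ccc3[nH]2)cc1` — in this assay compound 3 gives 15000 nM.

Compound 3 is thus the only one of the three with an actual number; the other two sit at the limit, so compound 3 is the least tolerated of the set. The step of an at least 6.6-fold lower number from compound 1 to compound 3 (0.82 log units; beyond the scatter) and the step of an at least 6.6-fold lower number from compound 2 to compound 3 (0.82 log units; beyond the scatter) both lead from the limit down to compound 3, and both are described by the limit of > 100000 nM in this assay, at which 2 of the 3 values shown sit.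

Compound 4 `CC(=O)Nc1ccc(-c2nc3cc(C(F)(F)F)ccc3[nH]2)cc1` has not yet been measured. It differs from compound 3 in one place: acetamido in place of methoxy on an aromatic carbon. Both measured steps run toward compound 3 from compounds at the limit, so a change away from the methoxy of compound 3 is expected to move back toward the limit. For compound 4 the step of a 4.0-fold higher number from compound 3 to compound 4 (0.60 log units; beyond the scatter) is therefore expected. Compound 4 is expected to give about 60000 nM in this assay, within a range from 15000 nM to 200000 nM.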

Compound 4, half-maximal cytotoxic concentration: 50000 nM
Beside the measured number, compound 4's estimate is 1.2-fold (0.08 log units) above it, within the range that was stated.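

In this assay, for the compounds shown here, the change from methoxy to acetamido gives a 3.3-fold higher number from compound 3 to compound 4 (0.52 log units; beyond the scatter), and this is the first step here with a real number at both ends, whereas each earlier step starts from a limit: the limit of > 100000 nM in this assay, at which 2 of the 4 values shown sit. At this place on the ring, para to a large group, methoxy now has the lowest number against two different replacements, hydroxy and acetamido, so the lower tolerance of compound 3 no longer rests on a comparison with hydroxy alone. Compound 1 gives > 100000 nM, a limit of the assay and not a number. The step of an at least 2.0-fold lower number from compound 1 to compound 4 (0.30 log units; that floor lies within the scatter) is all that can be said of this pair, and it does not put the two in order.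

The compounds shown leave open whether acetamido and hydroxy share something that lifts the number or reach it separately, as the data give no cause for the change. An amine or a longer chain such as ethoxy at the same place could show whether the number stays low only with methoxy, or whether other small groups give a similar result.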